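Swapping a Ring Amide for an Ethyl Amide

The source may hold more compounds than are shown below. What is called first, only, known or untested is meant among the compounds shown, and "the series" means these compounds.

Of the compounds shown here, three built on a shared core have been tested so far: compound 1 `N#C[C@@H]1CCCN1C(=O)[C@@H]1C[C@H](CO)CN1`, compound 2 `C=CC[C@@H]1CN[C@H](C(=O)N2CCC[C@H]2C#N)C1` and compound 3 `N#C[C@@H]1CCCN1C(=O)[C@@H]1C[C@H](C(=O)N2CCCCCCC2)CN1`. In an assay on the whole organism (plasma, strain Sprague-Dawley) for inhibition of Dipeptidyl peptidase 4 (Rattus norvegicus), with a stated time of 6 h, at a dose of 1 mg/kg by the oral route (on this read-out lower numbers stand for less inhibition and higher numbers for more inhibition at the one dose given (going by the name of the read-out)), compound 1 gives 64%, compound 2 gives 38% and compound 3 gives 63%. On these numbers compound 3 stands second highest: against compound 1 it differs by only a little, within the scatter, while against compound 2 it stands beyond the scatter. Among the measured compounds shown here, the one measured step, a number 26 percentage points lower from compound 1 to compound 2 (beyond the scatter), is a modest loss.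

Compound 4 `CCNC(=O)[C@@H]1CN[C@H](C(=O)N2CCC[C@H]2C#N)C1` differs from compound 3 in one place: a group of 3 heavy atoms (2 carbon, 1 nitrogen; no ring) in place of a group of 8 heavy atoms (7 carbon, 1 nitrogen; one eight-membered non-aromatic ring with 1 hetero atom), on a carbonyl carbon. For the measured compounds named here, no measured step mirrors this change, so the expectation rests on the observation that compound 1 and compound 3, which carry quite different groups at the same position, give numbers within the scatter of each other, and only compound 2 falls off. A small step, a number 5 percentage points lower from compound 3 to compound 4 (within the scatter), is therefore expected, with no clear direction beyond the scatter. Compound 4 is estimated at 58%, in a range from 40% to 72%.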

Compound 4, a percentage reported as inhibition, in the whole organism at one dose (the size of the read-out at that dose, not a potency): 60%
Compound 4: middle estimate off by 2 percentage points, on the low side, and the stated range covers the measured number.
By their numbers in this assay, from the lowest: compound 2; then compounds 4, 3 and 1 (each within the scatter of the next).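

On this carbonyl carbon, the ethylamino group can take the place of the much larger group with the eight-membered ring and the read-out in this assay stays within the scatter (a number 3 percentage points lower from compound 3 to compound 4 (within the scatter)), so that ring is not required for this level of inhibition at the one dose given. Among the compounds shown here, on the saturated ring carbon, ethylcarbamoyl and hydroxymethyl also cannot be told apart (a number 4 percentage points lower from compound 1 to compound 4 (within the scatter)), whereas ethylcarbamoyl in place of allyl makes a real difference (a number 22 percentage points higher from compound 2 to compound 4 (beyond the scatter)), which leaves the allyl of compound 2 as the one group here tied to a clear loss. No measurement is available that explains these results.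

Going by these compounds, whether a primary amine, a carboxylic acid or a longer chain on the saturated ring carbon would hold the read-out remains open. So does whether compounds that match at this one dose would still match at other doses.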